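A few compounds are considered here, and "the series" means these few. Any claim that something is new, unique, unknown or untested is made for them only; others in the source may bear on it.

Measured so far in an assay on isolated protein (strain Sprague-Dawley) for inhibition of Amine oxidase [flavin-containing] B (Rattus norvegicus), read by spectrophotometry, with a stated time of 5 min; on this read-out lower numbers stand for stronger inhibition and higher numbers for weaker inhibition:
compound 1, `CCOc1cc(=O)oc2cc(OCc3cccc(Br)c3)ccc12`: 126 nM
compound 2, `CC(=O)COc1cc(=O)oc2cc(OCc3cccc(Cl)c3)ccc12`: 26.9 nM
compound 3, `NC(=O)COc1cc(=O)oc2cc(OCc3cccc(Br)c3)ccc12`: 8.91 nM

Compound 2 stands second highest of the three numbers. Its nearest neighbour is compound 3, whose number is lower, and its furthest is compound 1, whose number is higher; both gaps lie beyond the scatter.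

The unmeasured compound 4, `N#Cc1cc(=O)oc2cc(OCc3cccc(Cl)c3)ccc12`, differs from compound 2 in one place: cyano in place of 2-oxopropoxy on an aromatic carbon. The group that leaves is the 2-oxopropoxy chain; the group that enters is the far smaller cyano.

Within the data shown here, no measured step matches this change. Among the measured compounds shown here, the only step recorded, a 14-fold lower number from compound 1 to compound 3 (1.15 log units; beyond the scatter), swaps a methyl for a carbamoyl on the chain while keeping the ether oxygen in place, so it shows how much the number can move at this position but not what removing the whole chain does. The three measured compounds all carry an oxygen-linked chain at this carbon, and the smallest of them, compound 1, gives the highest number. On that slim basis a move toward weaker inhibition seems the more likely outcome, though the size is uncertain.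

Compound 4 is therefore expected to give about 150 nM, within a range of 35 nM to 650 nM, which corresponds to an estimated step of a 5.6-fold higher number from compound 2 to compound 4 (0.75 log units; beyond the scatter).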

Compound 4, half-maximal inhibitory concentration: 102 nM
Beside the measured number, compound 4's estimate is 1.5-fold (0.17 log units) above it; measured number inside the range.
By their numbers in this assay, from the lowest: compound 3; then compound 2; then compounds 4 and 1 (each within the scatter of the next).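

In this assay, the change at this aromatic carbon gives a 3.8-fold higher number from compound 2 to compound 4 (0.58 log units; beyond the scatter), a modest step that is beyond the scatter. Among these compounds, this is the first view of this position without an oxygen-linked chain, and it shows that such a chain is not needed for inhibition in this set, since compound 4, with the much smaller cyano attached directly to the core, still gives 102 nM. The 2-oxopropoxy group does go with the lower number of this pair, but nothing available here accounts for the difference.

As far as these compounds go, it remains open whether the step would keep its size with bromine, the halogen of compound 1 and compound 3, in place of the chlorine shared by compound 2 and compound 4. The compounds shown also leave open how an amine, a carboxylic acid or a longer chain ending in a nitrile would compare with cyano and 2-oxopropoxy on this carbon, and so whether the number here follows the size of the group or something else about it.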